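The source may hold more compounds than are shown below. What is called first, only, known or untested is meant among the compounds shown, and "the series" means these compounds.

In a physicochemical assay for solubility (a higher number here means a more soluble compound, a lower number a less soluble compound), compound 1 `CNC(=O)c1cc(C(=O)NC2CC2)cn(CC2CCCCC2)c1=O` gives >= 148 ug/mL, which is a limit of the assay and not a number. Compound 2 `CNC(=O)c1cc(C(=O)NC2CC2)cn(Cc2cccc3c2CCN3)c1=O` gives >= 184 ug/mL, which is also a limit. Compound 2 therefore stands without an exact reading. Compound 3 `CNC(=O)c1cc(C(=O)NC2CC2)cn(Cc2ccccc2F)c1=O` has not yet been measured, and its structure differs from that of compound 2 in one place: 2-fluorophenyl in place of 2,3-dihydro-1H-indol-4-yl on a saturated chain carbon bound to an aromatic nitrogen. For the measured compounds named here, only one measured step bears on this change, because it alters the group at that same place: a step that the two limits leave unreadable from compound 1 to compound 2. With no readable size to go on, no step beyond the usual scatter is expected in this assay, and neither direction is favoured. The estimated change is an at least 1.0-fold lower number from compound 2 to compound 3 (0.03 log units; that floor lies within the scatter). For compound 3, the expected solubility is 170 ug/mL, with an estimated range from 90 ug/mL to 240 ug/mL.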

Compound 3, solubility: >= 145 ug/mL
Compound 3: no number, only a limit (the forecaster's own chance of this, stated with the estimate: 60%); the middle value is on the limit's open side.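

For the compounds shown here, compound 1, compound 2 and compound 3 each give only a limit in this assay and not a number, so no step between any two of them can be read. On these data alone, whether cyclohexyl, 2,3-dihydro-1H-indol-4-yl and 2-fluorophenyl give different solubilities on this core remains open.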